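Amine-to-amide switch on the benzylic nitrogen

A few compounds are considered here, and "the series" means these few. Any claim that something is new, unique, unknown or untested is made for them only; others in the source may bear on it.

Compound 3 `CCN[C@@H](CC(C)C)c1cc(C(F)(F)F)ccc1N1CCN(C(=O)CCc2ccc(Cl)cc2Cl)CC1` stands second highest of the three numbers in an assay on HEK293 cells for displacement of a labelled ligand from Melanocortin receptor 4 (Homo sapiens) (on this read-out higher numbers stand for weaker inhibition and lower numbers for stronger inhibition), giving 170 nM. Compound 1 `CCC(C)[C@H](NCCN)c1cc(C(F)(F)F)ccc1N1CCN(C(=O)CCc2ccc(Cl)cc2Cl)CC1` gives 56 nM and compound 2 `CCC(C)[C@H](NC(=O)OC)c1cc(C(F)(F)F)ccc1N1CCN(C(=O)CCc2ccc(Cl)cc2Cl)CC1` gives 2400 nM; accordingly a 3.0-fold higher number from compound 1 to compound 3 (0.48 log units; beyond the scatter) and a 14-fold lower number from compound 2 to compound 3 (1.15 log units; beyond the scatter). Compound 4 `CC(C)C[C@H](NC(=O)CCN)c1cc(C(F)(F)F)ccc1N1CCN(C(=O)CCc2ccc(Cl)cc2Cl)CC1` differs from compound 3 by (2-aminoethyl)carbonyl in place of ethyl on an amine nitrogen, so the amine becomes an amide. The step that bears on this is a 43-fold higher number from compound 1 to compound 2 (1.63 log units; beyond the scatter), where a carbonyl likewise entered on that nitrogen, with a 14-fold lower number from compound 2 to compound 3 (1.15 log units; beyond the scatter) reading the same change backwards. Compound 4 retains a terminal amine, which compound 1 also carries. A large upward step in this assay is therefore expected, though smaller than a 43-fold higher number from compound 1 to compound 2 (1.63 log units; beyond the scatter). Compound 4 is estimated at 850 nM, range 250 nM to 3000 nM. The estimate means an expected step of a 5.0-fold higher number from compound 3 to compound 4 (0.70 log units; beyond the scatter).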

Compound 4, inhibition constant: 25 nM
Compound 4: middle estimate off by 34-fold (1.53 log units), on the high side; the measured number lies below the stated range.
By their numbers in this assay, from the lowest: compound 4; then compound 1; then compound 3; then compound 2.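

A carbonyl on this amine nitrogen does not by itself weaken binding in this assay: (2-aminoethyl)carbonyl in place of ethyl gives a 6.8-fold lower number from compound 3 to compound 4 (0.83 log units; beyond the scatter), while the methoxycarbonyl carbamate stays far off (a 96-fold lower number from compound 2 to compound 4 (1.98 log units; beyond the scatter)). Against the amine that also carries a terminal amine, the amide gives a 2.2-fold lower number from compound 1 to compound 4 (0.35 log units; beyond the scatter), although the 3-methylbutyl and 2-methylbutyl frameworks also differ in that step. No measurement shown accounts for this outcome. Still open, from the compounds shown here alone, is whether the terminal amine is required, which an acetyl group would test, and how a longer aminoalkyl carbonyl chain compares.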